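This account rests on a few compounds, and the source may have more. Where it says the series, first, only, none or still open, it means among the compounds named here.

Measured compounds in an ADME assay on THP-1 cells (Homo sapiens) for cytotoxicity; on this read-out lower numbers stand for higher toxicity in this test and higher numbers for lower toxicity in this test:
- compound 1 `Cc1ccc([C@@H]2C[C@H](O)Cc3cc(Cl)ccc3N2)s1`: > 2040000 nM, which is a limit of the assay rather than a number
- compound 2 `Cc1ccc([C@@H]2C[C@H](O)Cc3cc(F)ccc3N2)s1`: 312000 nM

Compound 1 is known in this assay only as a limit, so its exact place on the scale is open; it sits at the limit of > 2040000 nM in this assay, at which 1 of the 2 values shown sits. Among the measured compounds shown here, the one measured step goes from compound 1 to compound 2, where fluoro replaces chloro on an aromatic carbon, and this gave an at least 6.5-fold lower number from compound 1 to compound 2 (0.81 log units; beyond the scatter).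

Compound 3 `Cc1ccc([C@@H]2C[C@H](O)Cc3cc(Cl)ccc3N2)o1` has not been measured. It differs from compound 1 by 5-methylfuran-2-yl in place of 5-methylthiophen-2-yl on a saturated ring carbon. For the measured compounds named here, no measured step touches this change: the only step known concerns the halogen on the aromatic ring, not the five-membered aromatic ring on the seven-membered ring. With nothing to point either way, and compound 1 known only as a limit, no shift beyond the usual scatter is expected from compound 1 to compound 3, that is a number no higher from compound 1 to compound 3 (the limit leaves the size open). Compound 3 is therefore estimated at 2040000 nM in this assay, within a range from 700000 nM to 4000000 nM.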

Compound 3, half-maximal cytotoxic concentration: > 1080000 nM
Compound 3 was reported as a limit (the forecaster's own chance of this, stated with the estimate: 60%); the middle value is on the limit's open side.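

In this assay, compound 1 and compound 3 are both known only as limits of the assay, and the step between them cannot be read. The compounds shown leave open whether 5-methylfuran-2-yl in place of 5-methylthiophen-2-yl shifts the number at all, and in which direction.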